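Removing the Methoxy Group from Compound 2

The source may report more compounds than this note shows. Statements on the series, on what has been measured and on what is new or still open speak of the compounds shown alone.

Compound 2 `COc1ccccc1-c1cccc(S(=O)(=O)N2CCC(N3CCC(C)CC3)CC2)c1` stands highest of the three numbers measured in a functional assay on DLD-1 cells (Homo sapiens) for antiproliferative activity, read by CellTiter-Glo, with a stated time of 72 h (a higher number here means a weaker inhibitor, a lower number a stronger inhibitor), where compound 2 gives 21 nM. Its nearest neighbour is compound 3 `Cc1cc(C)c(S(=O)(=O)N2CCC(N3CCC(CCO)CC3)CC2)c(C)c1`, which in this assay gives 19 nM, a difference within the scatter. Compound 1 `Cc1cc(C)c(S(=O)(=O)N2CCC(N3CCC(C)CC3)CC2)c(C)c1` is far away, giving 0.03 nM in this assay. Going by the values given here, the only step between measured compounds that differ in one place is a 630-fold higher number from compound 1 to compound 3 (2.80 log units; beyond the scatter), a change on the saturated ring rather than on the aromatic ring, so it speaks only indirectly to the present question. Compound 4 `CC1CCN(C2CCN(S(=O)(=O)c3cccc(-c4ccccc4)c3)CC2)CC1` differs from compound 2 in a single place: hydrogen in place of methoxy on an aromatic carbon. Among the compounds with values here, no measured pair shows this change on the aromatic ring, so no step size can be read from the data for it. The author therefore expects no step beyond the scatter, estimating a 1.1-fold lower number from compound 2 to compound 4 (0.02 log units; within the scatter). For compound 4 the estimate in this assay is 20 nM, with a range from 5 nM to 80 nM.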

Compound 4, half-maximal inhibitory concentration: 2 nM
For compound 4 the middle estimate is 10-fold (1.00 log units) above the measured one; measured number below the stated range.
By their numbers in this assay, from the lowest: compound 1; then compound 4; then compounds 3 and 2 (each within the scatter of the next).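

Exchanging methoxy for hydrogen at this place, on an aromatic carbon ortho to a large group, gives the first step shown on the aromatic part of these compounds: in this assay it is an 11-fold lower number from compound 2 to compound 4 (1.02 log units; beyond the scatter). The difference from 2-methoxyphenyl to phenyl is thus enough on its own to move the number beyond the scatter, with the phenyl compound the stronger inhibitor of the pair. No measurement shown gives a reason for this step.

The compounds shown leave open how fluorine, a hydroxyl or an amine on the same aromatic carbon would compare with hydrogen and methoxy, and whether a longer chain such as ethoxy would raise the number further. They also leave open whether methoxy on another carbon of that ring would give a step of similar size.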